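Cytotoxicity notes: from compound 2 to compound 3

The source may report more compounds than this note shows. Statements on the series, on what has been measured and on what is new or still open speak of the compounds shown alone.

Compound 1 `Cc1cc(N2CCN(C)CC2)c2ncc(CSCCc3ccccc3)n2c1` has no result in an ADME assay on HEL cells (Homo sapiens) for cytotoxicity, with a stated time of 3 days; on this read-out lower numbers stand for higher toxicity in this test and higher numbers for lower toxicity in this test; for compound 1 the entry in this assay is recorded as "not determined" (no result reported) and no number is given. Going by the values given here, compound 2 `Cc1cc(-n2ccnc2)c2ncc(CSCCc3ccccc3)n2c1` gives 20 ug/mL in this assay, the only number the series shows so far, so it stands alone and no step between measured compounds can be drawn. Compound 3 `Cc1cc(Sc2ccc(Cl)cc2)c2ncc(CSCCc3ccccc3)n2c1` is the next entry to be run in this assay. Its structural change from compound 2 is (4-chlorophenyl)sulfanyl in place of 1H-imidazol-1-yl on an aromatic carbon. Among the compounds with values here, with no measured step to lean on, the expectation for compound 3 rests on the single value of compound 2 alone. A modest shift toward higher toxicity in this assay is expected, of a size around the edge of the usual scatter rather than clearly beyond it, so the estimated step is a 2.0-fold lower number from compound 2 to compound 3 (0.30 log units; within the scatter). Compound 3 is expected to give 10 ug/mL in this assay, within the range 4 ug/mL to 30 ug/mL.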

Compound 3, minimum cytotoxic concentration: 4 ug/mL
Estimate against measurement, compound 3: 2.5-fold (0.40 log units) above, within the range that was stated.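

In this assay this position on the shared core turns out to be able to move the read-out: (4-chlorophenyl)sulfanyl in place of 1H-imidazol-1-yl gives a 5.0-fold lower number from compound 2 to compound 3 (0.70 log units; beyond the scatter) and this first readable step runs toward higher toxicity in this test. The swap changes several things at once, with a five-membered aromatic ring with 2 hetero atoms leaving and a six-membered aromatic ring of carbon only entering along with sulfur and chlorine, so this single step cannot assign the shift to any one of them. No measured evidence on the cause of the shift is at hand.

Any step involving compound 1 cannot be read. From the compounds shown here alone, how a simple amine, a carboxylic acid or a lone chlorine on this aromatic carbon would read remains open.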